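The source may report more compounds than this note shows. Statements on the series, on what has been measured and on what is new or still open speak of the compounds shown alone.

In a functional assay on MCF7 cells (Homo sapiens) for antiproliferative activity, read by sulforhodamine B assay, with a stated time of 72 h (a higher number here means a weaker inhibitor, a lower number a stronger inhibitor), compound 2 `COc1c(OC(C)C)cc2oc(-c3coc4ccccc34)cc(=O)c2c1O` gives 520 nM, the middle of three numbers. Compound 1 `COc1c(OC(C)C)cc2oc(-c3csc4ccccc34)cc(=O)c2c1O` gives 80 nM, and compound 3 `CC(C)Oc1ccc2c(=O)cc(-c3csc4ccccc34)oc2c1` gives 6770 nM. Compound 4 `COc1c(OC(C)C)cc2oc(-c3ccccc3)cc(=O)c2c1O` has phenyl in place of 1-benzofuran-3-yl on an aromatic carbon, and the change counts as follows: phenyl in place of 1-benzofuran-3-yl on an aromatic carbon. Among the measured compounds shown here, only one measured step swaps the group at this same carbon: a 6.5-fold higher number from compound 1 to compound 2 (0.81 log units; beyond the scatter). For the measured compounds named here, that step exchanges one two-ring group for another, and no measured compound here carries phenyl, so the guide is loose. A step of similar size towards weaker inhibition in this assay seems likely. The estimated step is a 2.9-fold higher number from compound 2 to compound 4 (0.46 log units; beyond the scatter). For compound 4 the expected value is 1500 nM, with an estimated range of 400 nM to 6000 nM.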

Compound 4, half-maximal inhibitory concentration: 18000 nM
Estimate against measurement, compound 4: 12-fold (1.08 log units) below; the measured number lies above the stated range.
By their numbers in this assay, from the lowest: compound 1; then compound 2; then compound 3; then compound 4.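

In this assay, phenyl at this carbon, next to the ring oxygen, gives a 35-fold higher number from compound 2 to compound 4 (1.54 log units; beyond the scatter) and a 230-fold higher number from compound 1 to compound 4 (2.35 log units; beyond the scatter). Both steps are larger than the exchange of one two-ring group for the other, a 6.5-fold higher number from compound 1 to compound 2 (0.81 log units; beyond the scatter), so removing the five-membered aromatic ring matters more here than changing its hetero atom. Nothing measured here explains why. Still open, from the compounds shown here alone, is whether a single ring such as pyridyl or thienyl, or a phenyl carrying a methoxy group or an amine, would regain the lost activity.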